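This account rests on a few compounds, and the source may have more. Where it says the series, first, only, none or still open, it means among the compounds named here.

Compound 1 `O=C(NO)c1cccc(/C=C/c2ccnc(-c3cc(F)ccc3O)c2)c1`: 3890 nM
Compound 2 `O=C(NO)c1ccc(/C=C/c2ccnc(-c3ccccc3O)c2)cc1`: 1450 nM
Compound 3 `Cc1ccc(-c2cc(/C=C/c3ccc(C(=O)NO)cc3)c(F)cn2)cc1`: > 10000 nM

In a functional assay on HCT-116 cells (Homo sapiens) for antiproliferative activity, read by CellTiter-Glo, with a stated time of 72 h (a lower number here means a stronger inhibitor, a higher number a weaker inhibitor), compound 2 gives 1450 nM, the lowest of the two numbers shown. Compound 1 gives 3890 nM, a gap beyond the usual scatter. For compound 3 the assay reports only a limit, (the limit of > 10000 nM in this assay, at which 1 of the 3 values shown sits). Compound 4 `O=C(NO)c1ccc(/C=C/c2ccnc(Br)c2)cc1` has not yet been measured in this assay. It differs from compound 2 in one place: bromo in place of 2-hydroxyphenyl on an aromatic carbon. For the measured compounds named here, no measured pair shows this change, so the size of the step can only be guessed. A rise in the number, toward a weaker inhibitor, is expected: a 3.4-fold higher number from compound 2 to compound 4 (0.54 log units; beyond the scatter). Compound 4 is estimated at 5000 nM, with a range from 1800 nM to 12000 nM.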

Compound 4, half-maximal inhibitory concentration: > 10000 nM
Compound 4: only a limit was reported; the forecaster's own chance of this, stated with the estimate: 25%; middle value at least 2.0-fold (0.30 log units) away from the limit.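

In this assay, the first step read at this position is bromo in place of 2-hydroxyphenyl next to the ring nitrogen, and it gives an at least 6.8-fold higher number from compound 2 to compound 4 (0.83 log units; beyond the scatter). A lone bromo there therefore does not retain the activity of compound 2. The result for compound 4 is a limit, so the step has a floor but no known size: the limit of > 10000 nM in this assay, at which 2 of the 4 values shown sit.

The compounds shown leave open whether the difference lies with the aromatic ring or with its hydroxyl. A plain phenyl or an amine at this position would help separate the two.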